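Series notes: thiophen-2-yl replacement in compound 3

This account rests on a few compounds, and the source may have more. Where it says the series, first, only, none or still open, it means among the compounds named here.

Compound 2 `COc1ccc(-c2cc(-c3cc(C(C)C)c(O)cc3C)[nH]c(=O)c2C#N)c(OC)c1` stands highest of the two numbers in hand: in a functional assay for inhibition, tested at 100 ug/mL (on this read-out higher numbers stand for a stronger effect at the one concentration tested and lower numbers for a weaker effect), compound 2 gives 58%. Compound 1 `Cc1cc(O)c(C(C)C)cc1-c1cc(-c2ccccc2[N+](=O)[O-])c(C#N)c(=O)[nH]1` is the nearest comparator, and in this assay compound 1 gives 37.5%. Going by the values given here, the only measured step, a number 20.5 percentage points higher from compound 1 to compound 2 (beyond the scatter), shows that exchanging the aryl group on this aromatic carbon can move the read-out beyond the scatter. Compound 3 `Cc1cc(O)c(C(C)C)cc1-c1cc(-c2cccs2)c(C#N)c(=O)[nH]1` is not yet measured and differs from compound 2 as thiophen-2-yl in place of 2,4-dimethoxyphenyl on an aromatic carbon. Among the compounds with values here, only the step from compound 1 to compound 2 bears on this change, and that step exchanged one six-membered aryl for another, so the five-membered thiophen-2-yl has no direct precedent here. Within the data shown here, a step of comparable size is plausible, and since compound 2 holds the highest number so far, the likelier direction is downward. For compound 3 the expected step is a number 16 percentage points lower from compound 2 to compound 3 (beyond the scatter). The estimate for compound 3 in this assay is 42%, with a range from 22% to 65%.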

Compound 3, a percentage reported as inhibition, at one concentration (the size of the read-out at that concentration, not a potency): 68%
Compound 3: middle estimate off by 26 percentage points, on the low side, outside the stated range (above it).
By their numbers in this assay, from the lowest: compound 1; then compounds 2 and 3 (each within the scatter of the next).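

At this position, on an aromatic carbon ortho to a cyano group and opposite the ring nitrogen, a five-membered aromatic ring with a sulfur atom can take the place of a six-membered aromatic ring of carbon only in this assay (a number 10 percentage points higher from compound 2 to compound 3 (within the scatter)). Thiophen-2-yl also separates clearly from 2-nitrophenyl (a number 30.5 percentage points higher from compound 1 to compound 3 (beyond the scatter)), so two different groups now stand beyond the scatter from 2-nitrophenyl. Nothing measured in hand explains this response.

On these data alone, whether the result extends to other five-membered rings, such as furan-2-yl, remains open, as does the effect of a non-aromatic group at this position, such as an amine or a carboxylic acid. A single concentration also leaves open whether compound 2 and compound 3 would separate across a concentration range.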